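The compounds below may be only part of what the source reports. "The series", "measured", "known", "first", "only" and "open" are said of these compounds alone.

Measured compounds:
- compound 1, `O=C(CN(C(=O)c1cccnc1)C1CCCCC1)Nc1cc(F)cc(F)c1`: > 25100 nM
- compound 2, `O=C(CN(C(=O)c1ccc(-n2ccnc2)cc1)C1CCCCC1)Nc1cc(F)cc(F)c1`: 631 nM
- compound 3, `O=C(CN(C(=O)c1ccc(-c2ccccn2)cc1)C1CCCOC1)Nc1cc(F)cc(F)c1`: 79.4 nM

All three share a core in which an amide-type nitrogen carries both an aryl carbonyl and a chain leading to the difluoroanilide. In an assay on HEK293 cells for inhibition of sodium- and chloride-dependent glycine transporter 1 (Homo sapiens), read by scintillation proximity assay (a lower number here means a stronger inhibitor, a higher number a weaker inhibitor), compound 1 gives only a limit, > 25100 nM, so no number is known for it (the limit of > 25100 nM in this assay, at which 1 of the 3 values shown sits). Compound 2 gives 631 nM in this assay. Compound 3 gives 79.4 nM in this assay, the lowest of the two numbers; the number for compound 2 is higher, and that gap lies beyond the usual scatter.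

Compound 4, `CCC(COC)N(CC(=O)Nc1cc(F)cc(F)c1)C(=O)c1ccc(-c2ccccn2)cc1`, keeps the pyridinyl-phenyl carbonyl of compound 3 and changes only the group on the amide-type nitrogen: 1-(methoxymethyl)propyl in place of oxan-3-yl on an amide-type nitrogen. The ring is opened into a branched chain with the same count of heavy atoms and the same single hydrogen-bond acceptor. For the measured compounds named here, no measured pair here shows the effect of such a ring-to-chain change, so the expectation rests on compound 3 alone. A small step is expected, if any, from compound 3 to compound 4, a 2.0-fold higher number from compound 3 to compound 4 (0.30 log units; within the scatter), leaning toward a slightly higher number. Compound 4 is therefore estimated at 160 nM in this assay, with a range from 40 nM to 630 nM.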

Compound 4, half-maximal inhibitory concentration in the sodium- and chloride-dependent glycine transporter 1 assay: 1260 nM
Compound 4: the middle estimate sits 7.9-fold (0.90 log units) below what was measured; the measured number lies above the stated range.
By their numbers in the sodium- and chloride-dependent glycine transporter 1 assay, from the lowest: compound 3; then compounds 2 and 4 (each within the scatter of the next). At a limit, above all of these: compound 1.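

In the sodium- and chloride-dependent glycine transporter 1 assay, opening the oxan-3-yl ring into 1-(methoxymethyl)propyl gives a 16-fold higher number from compound 3 to compound 4 (1.20 log units; beyond the scatter), so the group on this amide-type nitrogen matters a great deal, even though both groups have the same counts of heavy atoms and hydrogen-bond acceptors. This is the first pair shown that differs in one place, which makes it the first direct reading of what a change at this position does, and it shows that matching counts are no guide to the result here. In a physicochemical assay for solubility, read by chemiluminescence (on this read-out higher numbers stand for higher solubility and lower numbers for lower solubility), compound 3 gives 56 ug/mL and compound 4 gives 24 ug/mL. The opened chain also comes with lower solubility in the physicochemical assay: the measured solubility of compound 3, 56 ug/mL, and of compound 4, 24 ug/mL, a 2.3-fold lower number (0.37 log units; beyond the scatter).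

Only one ring and one chain are shown at this position with this carbonyl, so it stays open whether the ring itself or the placing of its oxygen accounts for the difference. As far as these compounds go, how a ring holding an amine, or a longer chain, would behave in the sodium- and chloride-dependent glycine transporter 1 assay and the physicochemical assay also remains unknown.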